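Taking the aromatic ring group out of compound 3

The source may report more compounds than this note shows. Statements on the series, on what has been measured and on what is new or still open speak of the compounds shown alone.

Among the compounds with values here, in an ADME assay on Vero cells (Chlorocebus sabaeus) for cytotoxicity, read by MTT assay, with a stated time of 72 h (a lower number here means that less compound is tolerated, a higher number that more compound is tolerated), compound 3 `COc1c(N2CCN(C/C(C)=N/Nc3ccccc3)C(C)C2)c(F)cc2c(=O)c(C(=O)O)cn(C3CC3)c12` gives 11.1 ug/mL as the only actual number so far. Compound 1 `COC(=O)CCN1CCN(c2c(F)cc3c(=O)c(C(=O)O)cn(C4CC4)c3c2OC)CC1C` stands at > 1000 ug/mL which is a limit and not a number. For compound 2 `CCOC(=O)CCN1CCN(c2c(F)cc3c(=O)c(C(=O)O)cn(C4CC4)c3c2OC)CC1C` the entry "not determined" (no result reported) gives no value. Compound 4 `COc1c(N2CCN(CC/C(C)=N/NC(N)=O)C(C)C2)c(F)cc2c(=O)c(C(=O)O)cn(C3CC3)c12` carries a group of 8 heavy atoms (4 carbon, 3 nitrogen, 1 oxygen; no ring) in place of a group of 10 heavy atoms (8 carbon, 2 nitrogen; one six-membered aromatic ring of carbon only), on a saturated chain carbon bound to an amine nitrogen in a ring when set against compound 3. Within the data shown here, one measured step bears on this: an at least 90-fold lower number from compound 1 to compound 3 (1.95 log units; beyond the scatter) was large, and there the same aromatic group came in. Compound 4 has a different ringless group from compound 1, so only part of that step is expected to return. The expected change is a 7.2-fold higher number from compound 3 to compound 4 (0.86 log units; beyond the scatter) as a moderate rise. For compound 4 the estimate is 80 ug/mL with an expected range from 15 ug/mL to 500 ug/mL in this assay here.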

Compound 4, half-maximal cytotoxic concentration: 31.3 ug/mL
Beside the measured number, compound 4's estimate is 2.6-fold (0.41 log units) above it, and the stated range covers the measured number.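

Putting a ringless group in place of the group with the six-membered aromatic ring gives a 2.8-fold higher number from compound 3 to compound 4 (0.45 log units; beyond the scatter) in this assay, so the aromatic ring does not account for the whole drop seen at this place. A different ringless group still brings an at least 31-fold lower number from compound 1 to compound 4 (1.50 log units; beyond the scatter), so lacking a ring is not enough to restore tolerance. The entry for compound 1 is a limit and not a number: the limit of > 1000 ug/mL in this assay, at which 1 of the 4 values shown sits.

The compounds shown leave open how a carboxylic acid or a simple amine in place of this group would fare. They also leave open whether a longer chain would shift the number.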